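The source may hold more compounds than are shown below. What is called first, only, known or untested is meant among the compounds shown, and "the series" means these compounds.

Compound 1 `CCOC(=O)CO/N=C(/c1ccc(OC)c(OC)c1OC)c1cccc2ccccc12` — > 20000 nM
Compound 2 `COc1ccc(/C(=N/OCC(=O)O)c2cccc3ccccc23)c(OC)c1OC` — > 20000 nM

In a functional assay on THP-1 cells (Homo sapiens) for inhibition, read by sulforhodamine B assay, with a stated time of 48 h (a lower number here means a stronger inhibitor, a higher number a weaker inhibitor), compound 1 gives only a limit, > 20000 nM. Compound 2 likewise gives only a limit in this assay, > 20000 nM. Among the compounds with values here, the one measured step, a step that the two limits leave unreadable from compound 1 to compound 2, therefore cannot be sized; both readings sit at the limit of > 20000 nM in this assay, at which 2 of the 2 values shown sit.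

Compound 3 `COc1ccc(/C(=N/OC(C)=O)c2cccc3ccccc23)c(OC)c1OC` differs from compound 2 by acetyl in place of carboxymethyl on an oxygen. Within the data shown here, no measured step bears on this change, and the only step available, a step that the two limits leave unreadable from compound 1 to compound 2, is itself unreadable, so no size or direction can be drawn from it. With compound 2 standing at the limit of > 20000 nM in this assay, at which 2 of the 2 values shown sit, the most that can be said is that compound 3 is expected to stay in the same region, and the expected step that the limit leaves unreadable from compound 2 to compound 3 is none beyond the scatter. Compound 3 is thus estimated at 30000 nM in this assay, within 8000 nM to 120000 nM, most likely reported again as a limit.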

Compound 3, half-maximal inhibitory concentration: > 20000 nM
Compound 3: only a limit was reported (the forecaster's own chance of this, stated with the estimate: 75%); the middle value does not contradict the limit.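

In this assay compound 3 gives only a limit, > 20000 nM. The steps among compound 1, compound 2 and compound 3 therefore cannot be read: the limit of > 20000 nM in this assay, at which 3 of the 3 values shown sit.

The compounds shown leave open whether the groups on this oxygen differ at all in inhibition, and what change to the shared core would give a measurable value.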